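A Small Change Carried From One Core to Another

A few compounds are considered here, and "the series" means these few. Any claim that something is new, unique, unknown or untested is made for them only; others in the source may bear on it.

Compound 1 `CNCC(=O)Nc1cc(OC)ccc1C(=O)c1ccc(OC)c2c1OC(C)(C)C=C2` and compound 2 `COc1ccc(C(=O)c2ccc(OC)c3c2OC(C)(C)C=C3)c(NC(=O)CN(C)C)c1` share one core; compound 3 `C=C(c1ccc(OC)cc1NC(=O)CN)c1ccc(OC)c2c1OC(C)(C)C=C2` and compound 4 `C=C(c1ccc(OC)cc1NC(=O)CNC)c1ccc(OC)c2c1OC(C)(C)C=C2` share another, and the difference between the two cores is not broken down here. In a functional assay on HeLa cells (Homo sapiens) for antiproliferative activity, read by MTT assay, with a stated time of 48 h (on this read-out higher numbers stand for weaker inhibition and lower numbers for stronger inhibition), compound 1 gives 870 nM and compound 2 gives 1050 nM, so the change methyl in place of hydrogen on an amine nitrogen made a 1.2-fold higher number from compound 1 to compound 2 (0.08 log units; within the scatter). In this assay compound 3 gives 120 nM. Compound 4 carries the same kind of change, (methyl in place of hydrogen on an amine nitrogen); here the nitrogen has one saturated chain carbon as its other neighbour, whereas in compound 2 it has two saturated chain carbons. Because the same kind of change earlier gave only a 1.2-fold higher number from compound 1 to compound 2 (0.08 log units; within the scatter), a step of similar small size is expected here: a 1.2-fold higher number from compound 3 to compound 4 (0.07 log units; within the scatter). Compound 4 is therefore estimated at 140 nM, with a likely range from 70 nM to 300 nM.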

Compound 4, half-maximal inhibitory concentration: 310 nM
The estimate for compound 4 lay 2.2-fold (0.35 log units) below the measured number; the measured number lies above the stated range.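

In this assay the methyl on the amine nitrogen gave a 2.6-fold higher number from compound 3 to compound 4 (0.41 log units; beyond the scatter). That step passes the scatter while the earlier one does not, yet the two steps themselves cannot be told apart: the same change on two cores in this assay, a 1.2-fold higher number (0.08 log units; within the scatter) from compound 1 to compound 2 and a 2.6-fold higher number (0.41 log units; beyond the scatter) from compound 3 to compound 4, 2.1-fold (0.33 log units) apart, within the scatter of two such steps. So the change can be carried from one core to the other without a measurable difference in its effect, but with only one pair on each core, this does not prove that the effect is identical, and it does not explain why either step has its size.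

As far as these compounds go, it remains open whether an ethyl group on this nitrogen would behave alike on both cores. The same question applies to a longer chain in place of the (methylamino)methyl group.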